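The source may hold more compounds than are shown below. What is called first, only, known or untested is meant among the compounds shown, and "the series" means these compounds.

In a functional assay on MOLT-4 cells (Homo sapiens) for antiproliferative activity, read by cell counting, with a stated time of 2 days (on this read-out higher numbers stand for weaker inhibition and lower numbers for stronger inhibition), compound 1 `COc1cccc(Nc2nc(N)c(C(=O)c3ccccc3)s2)c1` gives 1500 nM and compound 3 `COc1ccccc1C(=O)c1sc(Nc2ccccc2)nc1N` gives 1300 nM. Compound 2 `COc1cc(C(=O)c2sc(Nc3ccc(F)cc3)nc2N)cc(OC)c1OC` stands lowest of the three at 280 nM, the strongest inhibition measured so far, and clearly apart from both others. Compound 4 `COc1ccc(Nc2nc(N)c(C(=O)c3cc(OC)c(OC)c(OC)c3)s2)cc1` keeps all of compound 2 except one substituent: methoxy in place of fluoro on an aromatic carbon, para to a large group (methoxy in place of fluoro on an aromatic carbon). Within the data shown here, no measured pair here isolates this change, so its size remains uncertain. A modest change is the working expectation, with no clear direction and no shift beyond the scatter. The expected move is a 1.3-fold lower number from compound 2 to compound 4 (0.10 log units; within the scatter). For compound 4, the estimated value is 220 nM, with an expected range from 70 nM to 700 nM.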

Compound 4, half-maximal inhibitory concentration: 480 nM
Compound 4: the middle estimate sits 2.2-fold (0.34 log units) below what was measured; the measured number falls inside the stated range.
By their numbers in this assay, from the lowest: compounds 2 and 4 (each within the scatter of the next); then compounds 3 and 1 (each within the scatter of the next).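

Among these compounds, as the only pair here that differs in one place, this step gives a direct reading: going from 4-fluorophenyl to 4-methoxyphenyl gives a 1.7-fold higher number from compound 2 to compound 4 (0.23 log units; within the scatter). At this position, para to a large group, methoxy and fluoro therefore cannot be told apart in this assay. No other data here bear on this result.

Still open, on these data alone, is how an amine or a carboxylic acid would read at this position, and whether a longer chain such as butoxy would fit as well as methoxy.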